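The source may report more compounds than this note shows. Statements on the series, on what has been measured and on what is new or still open speak of the compounds shown alone.

Of the compounds shown here, three sharing one core have been measured in a functional assay on SMMC-7721 cells (Homo sapiens) for antiproliferative activity, read by MTT assay, with a stated time of 48 h; on this read-out lower numbers stand for stronger inhibition and higher numbers for weaker inhibition. Compound 1 `CC(C)=CCC[C@]1(C)/C=C/[C@@H](OC(=O)C=C(C)C)[C@](C)(O)/C=C/C(=O)/C(CCl)=C\C1` gives 840 nM, compound 2 `CSC(=S)OC/C1=C/C[C@](C)(CCC=C(C)C)/C=C/[C@@H](OC(=O)C=C(C)C)[C@](C)(O)/C=C/C1=O` gives 720 nM, and compound 3 `CCN(CC)C(=O)/C1=C/C[C@](C)(CCC=C(C)C)/C=C/[C@@H](OC(=O)C=C(C)C)[C@](C)(O)/C=C/C1=O` gives 13800 nM, the highest number of the three. Compound 4 `CC(C)=CCC[C@]1(C)/C=C/[C@@H](OC(=O)C=C(C)C)[C@](C)(O)/C=C/C(=O)/C(C(=O)N(C(C)C)C(C)C)=C\C1` differs from compound 3 by diisopropylamino in place of diethylamino on a carbonyl carbon, so that diethylcarbamoyl becomes diisopropylcarbamoyl. The closest measured steps, a 16-fold higher number from compound 1 to compound 3 (1.22 log units; beyond the scatter) and a 19-fold higher number from compound 2 to compound 3 (1.28 log units; beyond the scatter), are both large, but each brings in diethylcarbamoyl itself. Going by the values given here, no measured step changes the amino group on that carbonyl carbon. No step beyond the scatter is expected in this assay, and neither direction is favoured, though the uncertainty is wide. The expected change is a 1.1-fold higher number from compound 3 to compound 4 (0.04 log units; within the scatter). Compound 4 is estimated at 15000 nM, with an expected range of 5000 nM to 40000 nM.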

Compound 4, half-maximal inhibitory concentration: 17200 nM
Estimate against measurement, compound 4: 1.1-fold (0.06 log units) below, and the stated range covers the measured number.
By their numbers in this assay, from the lowest: compounds 2 and 1 (each within the scatter of the next); then compounds 3 and 4 (each within the scatter of the next).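

In this assay, going by these compounds alone, diisopropylamino in place of diethylamino on a carbonyl carbon gives a 1.2-fold higher number from compound 3 to compound 4 (0.10 log units; within the scatter) and so leaves the number within the scatter, the only measured change to the amino group at this carbonyl carbon. The large gaps to the other two compounds remain with diisopropylcarbamoyl, at a 20-fold higher number from compound 1 to compound 4 (1.31 log units; beyond the scatter) and a 24-fold higher number from compound 2 to compound 4 (1.38 log units; beyond the scatter) as the printed steps show. As far as these compounds go, it remains open whether dimethylamino, piperidine, morpholine or a carboxylic acid at this carbonyl carbon would stay in the same range. No evidence is available to explain these results.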